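The source may report more compounds than this note shows. Statements on the series, on what has been measured and on what is new or still open speak of the compounds shown alone.

Measured in a physicochemical assay for solubility, read by HPLC, using the shake flask method, in phosphate buffer, with a stated time of 20 h, at pH 6.5; a higher number here means a more soluble compound, a lower number a less soluble compound:
- compound 1 `Fc1cc(F)cc(-c2nc3c(N4CCC(CN5CCNCC5)CC4)nccc3[nH]2)c1`: 190000 nM
- compound 2 `Fc1cc(F)cc(-c2nc3c(N4CCC(CN5CCC(F)(F)CC5)CC4)nccc3[nH]2)c1`: < 5000 nM, a limit of the assay
- compound 3 `Cn1ccnc1N1CCN(CC2CCN(c3nccc4[nH]c(-c5cc(F)cc(F)c5)nc34)CC2)CC1`: 135000 nM

Compound 3 shares the high end of this small series with compound 1, the measured step being a 1.4-fold lower number from compound 1 to compound 3 (0.15 log units; within the scatter). The limit lies far off, with an at least 27-fold higher number from compound 2 to compound 3 (1.43 log units; beyond the scatter).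

Compound 4 `CC(C)(C)N1CCN(CC2CCN(c3nccc4[nH]c(-c5cc(F)cc(F)c5)nc34)CC2)CC1` differs from compound 3 in one place: tert-butyl in place of 1-methyl-1H-imidazol-2-yl on an amine nitrogen in a ring. In words, this is tert-butyl in place of 1-methyl-1H-imidazol-2-yl on an amine nitrogen in a ring. For the measured compounds named here, the closest precedent is the change on that same nitrogen, where compound 3 gained its substituent from compound 1 with a 1.4-fold lower number from compound 1 to compound 3 (0.15 log units; within the scatter). The large step, an at least 38-fold lower number from compound 1 to compound 2 (1.57 log units; beyond the scatter), replaced the piperazin-1-yl itself, and compound 4 keeps that ring, so this step bears on it less directly. In this assay, no step beyond the scatter is therefore expected, with a slight drift to a lower number at most. The expected step is a 1.2-fold lower number from compound 3 to compound 4 (0.09 log units; within the scatter). For compound 4 the estimated value is 110000 nM, with an expected range from 40000 nM to 200000 nM.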

Compound 4, solubility: 185000 nM
The estimate for compound 4 lay 1.7-fold (0.23 log units) below the measured number, and the stated range covers the measured number.
By their numbers in this assay, from the lowest: compounds 3, 4 and 1 (each within the scatter of the next). At a limit, below all of these: compound 2.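

In this assay, the ring nitrogen of the piperazine carries tert-butyl without any step beyond the scatter, either against 1-methyl-1H-imidazol-2-yl, with a 1.4-fold higher number from compound 3 to compound 4 (0.14 log units; within the scatter), or against hydrogen, with a 1.0-fold lower number from compound 1 to compound 4 (0.01 log units; within the scatter). Across compounds 1, 3 and 4, then, this nitrogen holds hydrogen, a five-membered aromatic ring with 2 hetero atoms, or a group with no ring and no hydrogen-bond acceptors, and the numbers stay within the scatter of each other. The one large step here again involves the 4,4-difluoropiperidin-1-yl, an at least 37-fold higher number from compound 2 to compound 4 (1.56 log units; beyond the scatter), and it starts from a limit: the limit of < 5000 nM in this assay, at which 1 of the 4 values shown sits.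

Going by these compounds, how far that limit lies from a true number stays open. So does whether an acetyl group or a carboxylic acid on the same nitrogen would also stay within the scatter of compounds 1, 3 and 4.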